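Removing Urea Nitrogen and Halogens: Expectations for Compound 4

This account rests on a few compounds, and the source may have more. Where it says the series, first, only, none or still open, it means among the compounds named here.

Of the compounds shown here, three sharing one core have been tested in a functional assay on SW-620 cells (Homo sapiens) for inhibition, read by sulforhodamine B assay, with a stated time of 48 h; a higher number here means a weaker inhibitor of growth, a lower number a stronger inhibitor of growth. Compound 1, `COc1cc(-c2nn(-c3cccc(NC(=O)c4cccc(C(F)(F)F)c4)c3)cc2-c2ccncc2)ccc1Cl`, carries an amide bearing a 3-(trifluoromethyl)phenyl group; in this assay compound 1 gives only a limit, > 50000 nM. Compound 2, `COc1cc(-c2nn(-c3cccc(NC(=O)c4ccc(Cl)c(C(F)(F)F)c4)c3)cc2-c2ccncc2)ccc1Cl`, differs from it by chloro in place of hydrogen on an aromatic carbon; in this assay compound 2 also reaches only a limit, > 32500 nM. Among the measured compounds shown here, compound 3, `COc1cc(-c2nn(-c3cccc(NC(=O)Nc4ccc(Cl)c(C(F)(F)F)c4)c3)cc2-c2ccncc2)ccc1Cl`, replaces the amide with a urea, and in this assay compound 3 gives 29900 nM, the only true number among the three. The step of an at least 1.6-fold lower number from compound 1 to compound 3 (0.22 log units; that floor lies within the scatter) and the step of an at least 1.0-fold lower number from compound 2 to compound 3 (0.03 log units; that floor lies within the scatter) are each only a floor set by those limits, so whether compound 3 is truly the stronger inhibitor is not settled.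

Compound 4, `COc1cc(-c2nn(-c3cccc(NC(=O)c4ccccc4)c3)cc2-c2ccncc2)ccc1Cl`, moves the other way: phenyl in place of (4-chloro-3-(trifluoromethyl)phenyl)amino on a carbonyl carbon. This removes the urea nitrogen together with the chloro and trifluoromethyl groups, leaving an amide with an unsubstituted phenyl. Compound 1, the nearest measured amide, reached only a limit. The steps toward compound 3 were small at best, so compound 4 is expected to give a weaker number than compound 3, quite possibly again at a limit. The expected step is a 1.7-fold higher number from compound 3 to compound 4 (0.22 log units; within the scatter). Compound 4 is estimated at 50000 nM, within 20000 nM to 100000 nM.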

Compound 4, concentration for total growth inhibition: > 100000 nM
Compound 4 ended at the assay's limit (the forecaster's own chance of this, stated with the estimate: 60%); middle value at least 2.0-fold (0.30 log units) away from the limit.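

In this assay, phenyl in place of (4-chloro-3-(trifluoromethyl)phenyl)amino on the carbonyl carbon gives an at least 3.3-fold higher number from compound 3 to compound 4 (0.52 log units; beyond the scatter), the first step among these compounds that lies beyond the scatter. This shows that the group at this place can change the read-out: the urea compound 3 gives a true number, whereas the amide with an unsubstituted phenyl, compound 4, gives only a limit, so the real step could be larger than this floor. Both ends of the steps from compound 1 and from compound 2 to compound 4 are limits, so those steps cannot be read.

This one change removes the urea nitrogen, the chloro and the trifluoromethyl together, so the compounds shown cannot say which of these parts accounts for the step. A urea ending in an unsubstituted phenyl would begin to separate them, and a carboxylic acid or an amine on that terminal ring would test whether groups of a quite different kind can give a true number at all.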